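A few compounds are considered here, and "the series" means these few. Any claim that something is new, unique, unknown or untested is made for them only; others in the source may bear on it.

Compound 2 `CCC(C)(C)Cc1c[nH]c(CCc2ccc(-c3cccnc3)cc2)n1` gives the lowest number of the three compounds measured in an in vitro assay on CHO cells for displacement of a labelled ligand from Bombesin receptor subtype-3 (Homo sapiens), read by scintillation counting, with a stated time of 2 h (a lower number here means a stronger inhibitor, a higher number a weaker inhibitor), at 7.5 nM. Compound 3 `O=C(O)c1cc(F)c(F)cc1-c1ccc(CCc2nc(CC3CCCCC3)c[nH]2)cc1` comes nearest in this assay with 36 nM, a gap that lies beyond the scatter, and compound 1 `c1ccc(-c2ccc(CCc3nc(CC4CCCC4)c[nH]3)cc2)nc1` stands furthest away with 177 nM in this assay. Compound 4 `CCC(C)(C)Cc1c[nH]c(CCc2ccc(-n3cccn3)cc2)n1` has not yet been measured; it differs from compound 2 in a single place: 1H-pyrazol-1-yl in place of pyridin-3-yl on an aromatic carbon. For the measured compounds named here, no pair of measured compounds shares this change, so the size of its effect cannot be read from the data. A modest shift toward a higher number in this assay is expected, a 2.7-fold higher number from compound 2 to compound 4 (0.43 log units; beyond the scatter). Compound 4 is accordingly estimated at 20 nM, with a likely range from 6 nM to 70 nM.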

Compound 4, half-maximal inhibitory concentration: 33 nM
The estimate for compound 4 lay 1.7-fold (0.22 log units) below the measured number, within the range that was stated.
By their numbers in this assay, from the lowest: compound 2; then compounds 4 and 3 (each within the scatter of the next); then compound 1.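

On this aromatic carbon, para to a large group, replacing pyridin-3-yl with 1H-pyrazol-1-yl gives a 4.4-fold higher number from compound 2 to compound 4 (0.64 log units; beyond the scatter) in this assay. For the compounds shown here, this is the first step at this position that can be read with the rest of the molecule unchanged, and it shows that the choice of aromatic ring here moves the number beyond the scatter. No available evidence accounts for the size of this step. Open, going by these compounds, is how a pyrimidin-5-yl or an amide on this carbon would compare, and whether this exchange gives a similar step with a different group on the shared core.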